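Indole-terpene esters: halogen swap at the aromatic ring

The source may report more compounds than this note shows. Statements on the series, on what has been measured and on what is new or still open speak of the compounds shown alone.

Measured so far:
compound 1 `COC(=O)[C@@]1(C)CCC=C2[C@@H]1CC[C@@H](C)[C@]2(C)Cc1c[nH]c2ccc(Cl)cc12` — 11000 nM
compound 2 `COC(=O)[C@@]1(C)CCC=C2[C@@H]1CC[C@@H](C)[C@]2(C)Cc1c[nH]c2ccc(F)cc12` — 7300 nM
compound 3 `COC(=O)[C@@]1(C)CC[C@@H]2C3=C1CC[C@@H](C)[C@]3(C)C[C@@H]1c3cc(Cl)ccc3N[C@H]21` — 38000 nM

All three were run in a functional assay on SW1573 cells (Homo sapiens) for inhibition, read by sulforhodamine B assay, with a stated time of 48 h; on this read-out lower numbers stand for stronger inhibition of growth and higher numbers for weaker inhibition of growth. Compound 1 gives 11000 nM and its fluoro counterpart, compound 2, gives 7300 nM. The change between them is fluoro in place of chloro on an aromatic carbon. The step it made is a 1.5-fold lower number from compound 1 to compound 2 (0.18 log units; within the scatter), so on this read-out the two halogens are not told apart.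

Compound 3 carries the same atoms as compound 1 joined differently; the difference between the two cores is not broken down here. In this assay compound 3 gives 38000 nM, the highest of the three numbers, and its distance from compound 1 and from compound 2 lies beyond the scatter.

Compound 4 `COC(=O)[C@@]1(C)CC[C@@H]2C3=C1CC[C@@H](C)[C@]3(C)C[C@@H]1c3cc(F)ccc3N[C@H]21` is not yet measured. Within the data shown here, it differs from compound 3 by fluoro in place of chloro on an aromatic carbon, the same kind of change as the one from compound 1 to compound 2, but here the aromatic carbon belongs to a fused or bridged system of five rings rather than two. The step from compound 3 to compound 4 is expected to be a 1.5-fold lower number from compound 3 to compound 4 (0.18 log units; within the scatter), resting on the single earlier case where the same kind of change gave a 1.5-fold lower number from compound 1 to compound 2 (0.18 log units; within the scatter). Compound 4 is thus estimated at 25000 nM in this assay. For compound 4 the likely range is estimated as 10000 nM to 60000 nM.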

Compound 4, concentration for 50% growth inhibition: 27000 nM
Compound 4: the middle estimate sits 1.1-fold (0.03 log units) below what was measured; low and high end bracket the measured number.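

In this assay, fluoro in place of chloro on an aromatic carbon of the fused or bridged system of five rings gives a 1.4-fold lower number from compound 3 to compound 4 (0.15 log units; within the scatter). Set beside the earlier case on the other core, the change reads the same on both: the same change on two cores in this assay, a 1.5-fold lower number (0.18 log units; within the scatter) from compound 1 to compound 2 and a 1.4-fold lower number (0.15 log units; within the scatter) from compound 3 to compound 4, 1.1-fold (0.03 log units) apart, within the scatter of two such steps. Among these compounds, this shows only that the exchange carries over between these two cores in the sense that neither step separates the two halogens; it does not show a real gain from fluoro on either core, and one pair per core in a single cell assay gives no rule for other cores or other changes.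

The compounds shown hold only chloro or fluoro on this aromatic carbon, so it remains open whether the bare hydrogen, a bromo, a methoxy or a nitrile there would give a step beyond the scatter on either core. On these data alone, all four also carry the same methyl ester, and what a carboxylic acid or an amide in its place would do to growth inhibition, and whether any such step would carry from one core to the other, also stays open.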